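Trifluoromethoxy in place of cyano in an antiproliferative series

The compounds below may be only part of what the source reports. "The series", "measured", "known", "first", "only" and "open" are said of these compounds alone.

Within the data shown here, in a functional assay on MDA-MB-231 cells (Homo sapiens) for antiproliferative activity, read by MTT assay, with a stated time of 24 h (on this read-out lower numbers stand for stronger inhibition and higher numbers for weaker inhibition), compound 2 (`N#Cc1ccc(S(=O)(=O)NC(CC(=O)O)c2ccccc2)cc1`) gives 48700 nM, the only actual number so far. Compound 1 (`CC(C)(C)c1ccc(S(=O)(=O)NC(CC(=O)O)c2ccccc2)cc1`) gives > 100000 nM, which is a limit of the assay and not a number. Among the measured compounds shown here, the one measured step, an at least 2.0-fold lower number from compound 1 to compound 2 (0.31 log units; beyond the scatter), replaces tert-butyl with cyano and is itself bounded by that limit, so it offers only a loose guide. Compound 3 (`O=C(O)CC(NS(=O)(=O)c1ccc(OC(F)(F)F)cc1)c1ccccc1`) carries trifluoromethoxy in place of cyano on an aromatic carbon. The expected change, a 1.4-fold higher number from compound 2 to compound 3 (0.16 log units; within the scatter), is no step beyond the scatter. Compound 3 is estimated at 70000 nM, with an expected range of 25000 nM to 120000 nM.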

Compound 3, half-maximal inhibitory concentration: > 100000 nM
Compound 3 ended at the assay's limit; the forecaster's own chance of this, stated with the estimate: 35%; middle value at least 1.4-fold (0.15 log units) from the limit.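

Trifluoromethoxy in place of cyano gives an at least 2.0-fold higher number from compound 2 to compound 3 (0.31 log units; beyond the scatter) in this assay, and this step is bounded by a limit of the assay, so its full size cannot be told. Of the three groups on this aromatic carbon, para to a large group, only cyano has given an actual number, while tert-butyl and trifluoromethoxy both end at the limit: the limit of > 100000 nM in this assay, at which 2 of the 3 values shown sit. The step between compound 1 and compound 3 cannot be read, as both values are limits. The compounds shown leave open whether an amine or a methoxy group at this place would give a lower number than compound 2 does.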